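The source may report more compounds than this note shows. Statements on the series, on what has been measured and on what is new or still open speak of the compounds shown alone.

Measured so far:
compound 1 `Cn1ncc2c1NC(=O)CN=C2c1ccccc1` — 250 mg/kg
compound 2 `Cc1nn(C)c2c1C(c1ccccc1Cl)=NCC(=O)N2` — 16 mg/kg
compound 3 `CCc1nn(C)c2c1C(c1cccc(F)c1)=NCC(=O)N2` — 32 mg/kg

In a functional assay on the whole organism with Rattus norvegicus as the target (a higher number here means that more compound is needed for the effect, a lower number that less compound is needed), compound 1 gives 250 mg/kg, the highest of the three numbers. Its nearest neighbour is compound 3 with 32 mg/kg, a gap beyond the scatter, and compound 2 with 16 mg/kg lies further still, also beyond the scatter. The two lower values belong to compounds that carry an alkyl group on the five-membered ring of the shared core and a halogen on the phenyl ring, so the three numbers do not isolate either change.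

Compound 4 `Cn1nc(Cl)c2c1NC(=O)CN=C2c1ccccc1` is not yet measured. It differs from compound 1 by chloro in place of hydrogen on an aromatic carbon. Within the data shown here, no measured pair shows this change on its own, so the step can only be expected, not read off. Both compounds with a substituent on that aromatic carbon show lower numbers than compound 1, which suggests a step downward in this assay from compound 1 to compound 4, of modest size, though the halogens on the phenyl rings of compound 2 and compound 3 may account for part of that gap. Compound 4 is therefore expected to give about 100 mg/kg, with a likely range of 30 mg/kg to 300 mg/kg, which corresponds to an estimated step of a 2.5-fold lower number from compound 1 to compound 4 (0.40 log units; beyond the scatter).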

Compound 4, minimum effective dose: 63 mg/kg
For compound 4 the middle estimate is 1.6-fold (0.20 log units) above the measured one; the measured number falls inside the stated range.
By their numbers in this assay, from the lowest: compounds 2, 3 and 4 (each within the scatter of the next, the first and the last beyond it); then compound 1.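

In this assay, among these compounds, the pair formed by compound 1 and compound 4 gives the first reading of a single change, with a 4.0-fold lower number from compound 1 to compound 4 (0.60 log units; beyond the scatter) on exchanging hydrogen for chloro. It shows that a substituent on this aromatic carbon of the five-membered ring can move the number beyond the scatter with the unsubstituted phenyl ring left as it is, which compound 2 and compound 3 could not show, as each also differs from compound 1 on the phenyl ring. Nothing given here accounts for the size or direction of this step.

The compounds shown leave open whether another group on the same carbon, such as a methyl, an ethyl, a bromo, an amine or a carboxylic acid, would on its own give a step of similar size or direction. They also leave open whether chloro on this carbon would give a comparable step in a compound that carries a halogen on the phenyl ring.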